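The source may hold more compounds than are shown below. What is called first, only, known or untested is meant among the compounds shown, and "the series" means these compounds.

Compound 1 `COc1ccc(-c2sc(C(=O)O)cc2-c2cc(OC)c(OC)c(OC)c2)cc1`, compound 2 `COc1ccc(-c2sc(C(=O)O)cc2-c2cc(OC)c(OC)c(OC)c2)cc1[N+](=O)[O-]` and compound 3 `COc1ccc(-c2sccc2-c2cc(OC)c(OC)c(OC)c2)cc1` were tested in a functional assay on KB cells (Homo sapiens) for antiproliferative activity, read by MTT assay, with a stated time of 72 h; a lower number here means a stronger inhibitor, a higher number a weaker inhibitor. Compound 1 gives 10400 nM, compound 2 gives 35900 nM, and compound 3 gives 8880 nM. The change nitro in place of hydrogen on an aromatic carbon produced a 3.5-fold higher number from compound 1 to compound 2 (0.54 log units; beyond the scatter). The two cores differ in hydrogen in place of carboxy on an aromatic carbon, and that difference gave a 1.2-fold lower number from compound 1 to compound 3 (0.07 log units; within the scatter), so the carboxy group leaves the number essentially where it was. Compound 4 `COc1ccc(-c2sccc2-c2cc(OC)c(OC)c(OC)c2)cc1[N+](=O)[O-]` has not yet been measured. It differs from compound 3 by nitro in place of hydrogen on an aromatic carbon, the same change in the same place that separates compound 1 from compound 2. For compound 4 in this assay the step is expected to be a 3.4-fold higher number from compound 3 to compound 4 (0.53 log units; beyond the scatter), because the same change on the other core made a 3.5-fold higher number from compound 1 to compound 2 (0.54 log units; beyond the scatter). Compound 4 is accordingly estimated at 30000 nM, with a range from 12000 nM to 75000 nM.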

Compound 4, half-maximal inhibitory concentration: 10600 nM
Estimate against measurement, compound 4: 2.8-fold (0.45 log units) above, and the stated range ends above it.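

On the core without the carboxy group, nitro in place of hydrogen gives a 1.2-fold higher number from compound 3 to compound 4 (0.08 log units; within the scatter) in this assay, so the step seen on the core of compound 1 did not carry over: the same change on two cores in this assay, a 3.5-fold higher number (0.54 log units; beyond the scatter) from compound 1 to compound 2 and a 1.2-fold higher number (0.08 log units; within the scatter) from compound 3 to compound 4, 2.9-fold (0.46 log units) apart, beyond the scatter of two such steps. Read the other way, hydrogen in place of carboxy gives a 3.4-fold lower number from compound 2 to compound 4 (0.53 log units; beyond the scatter) when the nitro group is present, and the size of this step also depends on the core: the same change on two cores in this assay, a 1.2-fold lower number (0.07 log units; within the scatter) from compound 1 to compound 3 and a 3.4-fold lower number (0.53 log units; beyond the scatter) from compound 2 to compound 4, 2.9-fold (0.46 log units) apart, beyond the scatter of two such steps. These two pairs show that neither step can be carried unchanged between these two cores in this assay, but they do not show why, or how either change would behave on any other core.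

The compounds shown leave open whether an amine in place of the nitro group would also give steps that differ between the two cores. They also leave open whether a methyl ester in place of the carboxy group would do the same.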